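Ortho versus para substituents on the pendant phenyl ring

A few compounds are considered here, and "the series" means these few. Any claim that something is new, unique, unknown or untested is made for them only; others in the source may bear on it.

Measured so far:
compound 1 `COc1ccc(-c2cn3ccnc3c(-c3ccc4ncn(C5CCCCC5)c4c3)n2)cc1` gives 58.8% in a functional assay on OVCAR-5 cells (Homo sapiens) for inhibition, read by sulforhodamine B assay, with a stated time of 48 h, tested at 10 uM; on this read-out higher numbers stand for more inhibition at the one concentration tested (going by the name of the read-out) and lower numbers for less inhibition;
compound 2 `COc1ccccc1-c1cn2ccnc2c(-c2ccc3ncn(C4CCCCC4)c3c2)n1` gives 6.61% in this assay.

Compound 1 stands highest of the two numbers; the nearest is compound 2, reached by a number 52.2 percentage points lower from compound 1 to compound 2 (beyond the scatter). Compound 3 `Fc1ccccc1-c1cn2ccnc2c(-c2ccc3ncn(C4CCCCC4)c3c2)n1` is not yet measured. Its change from compound 1 is 2-fluorophenyl in place of 4-methoxyphenyl on an aromatic carbon. Going by the values given here, the only measured step that bears on it is the one from compound 1 to compound 2, where a 2-methoxyphenyl likewise replaced the 4-methoxyphenyl and the drop was large. A substituent at the 2-position again enters here, so a large drop is expected in this assay, though 2-fluorophenyl differs from 2-methoxyphenyl and the size is uncertain. Compound 3 is therefore estimated at 20% (range 0% to 50%), the expected step being a number 38.8 percentage points lower from compound 1 to compound 3 (beyond the scatter).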

Compound 3, a percentage reported as inhibition, at one concentration (the size of the read-out at that concentration, not a potency): 6.64%
Estimate against measurement, compound 3: 13.4 percentage points above; measured number inside the range.
By their numbers in this assay, from the lowest: compounds 2 and 3 (each within the scatter of the next); then compound 1.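

In this assay, 2-fluorophenyl also costs much of the inhibition, a number 52.2 percentage points lower from compound 1 to compound 3 (beyond the scatter), so the loss is not confined to 2-methoxyphenyl. Fluoro and methoxy cannot be told apart on the 2-substituted phenyl, a number 0 percentage points higher from compound 2 to compound 3 (within the scatter). No measurement available here explains this shared loss.

The compounds shown do not separate an effect of substitution at the 2-position from the loss of the 4-methoxyphenyl itself. Unsubstituted phenyl, or a dimethylamino group replacing the methoxy of the 4-methoxyphenyl, remains open.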